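The source may report more compounds than this note shows. Statements on the series, on what has been measured and on what is new or still open speak of the compounds shown alone.

Compound 1 `CC(C)(C)OC(=O)n1c(-c2ccc3c(c2)CC(NS(=O)(=O)c2ccccc2)C3)cc2ccccc21` gives 680 nM
Compound 2 `CC(C)(C)OC(=O)n1c(-c2ccc3c(c2)CC(NS(=O)(=O)c2ccc(F)cc2)C3)cc2ccccc21` gives 570 nM
Compound 3 `CC(C)(C)OC(=O)n1c(-c2ccc3c(c2)CC(NS(=O)(=O)c2cccs2)C3)cc2ccccc21` gives 570 nM

In a functional assay on THP-1 cells (Homo sapiens) for activation, with a stated time of 18 h (on this read-out higher numbers stand for an effect only at larger amounts of compound and lower numbers for an effect already at smaller amounts), compound 2 and compound 3 read the same, and compound 1 lies within the scatter of both. Compound 4 `CC(C)(C)OC(=O)n1c(-c2ccc3c(c2)CC(NS(=O)(=O)c2ccc(-c4ccon4)s2)C3)cc2ccccc21` is compound 3 with 1,2-oxazol-3-yl in place of hydrogen on an aromatic carbon of the sulfur-containing ring, so thiophen-2-yl becomes 5-(1,2-oxazol-3-yl)thiophen-2-yl: 1,2-oxazol-3-yl in place of hydrogen on an aromatic carbon.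

Within the data shown here, three measured steps touch this part of the molecule. Changing the group on the sulfonyl sulfur gave a 1.2-fold lower number from compound 1 to compound 3 (0.08 log units; within the scatter) and no change at the digits printed from compound 2 to compound 3 (within the scatter), while adding fluoro gave a 1.2-fold lower number from compound 1 to compound 2 (0.08 log units; within the scatter). All three are small, which suggests that this end of the molecule tolerates change, but none of them adds a whole ring. The range must therefore stay wide.

No shift beyond the scatter is expected in this assay, and the expected step is a 1.1-fold lower number from compound 3 to compound 4 (0.06 log units; within the scatter). The estimate for compound 4 is 500 nM, with an expected range from 160 nM to 1500 nM.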

Compound 4, half-maximal effective concentration: 590 nM
Estimate against measurement, compound 4: 1.2-fold (0.07 log units) below; the range from low to high includes it.
By their numbers in this assay, from the lowest: compounds 2, 3, 4 and 1 (each within the scatter of the next).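

Until now the steps at this end of the molecule had only exchanged one ring for another or added fluoro. Compound 4 shows that a whole 1,2-oxazol-3-yl ring can be added next to the ring sulfur while the read-out in this assay stays within the scatter (a 1.0-fold higher number from compound 3 to compound 4 (0.01 log units; within the scatter)), and the comparisons with the two other compounds read the same way (a 1.0-fold higher number from compound 2 to compound 4 (0.01 log units; within the scatter); a 1.2-fold lower number from compound 1 to compound 4 (0.06 log units; within the scatter)). Nothing available here gives a reason for this flat result.

Going by these compounds, whether an amine, a carboxylic acid or a longer chain on this same aromatic carbon would also stay within the scatter remains open. On these data alone, it is also open whether 1,2-oxazol-3-yl would read the same way on the phenyl ring of compound 1.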